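A few compounds are considered here, and "the series" means these few. Any claim that something is new, unique, unknown or untested is made for them only; others in the source may bear on it.

Measured compounds:
- compound 1 `CNC(=O)c1cc(C(=O)N[C@H]2[C@@H]3C[C@@H](O)C[C@@H]32)n([C@@H](C)c2cccc(Cl)c2)n1`: < 0.65 mL/min
- compound 2 `CNC(=O)c1cc(C(=O)N[C@H]2CC[C@H](O)CC2)n([C@@H](C)c2ccccc2)n1`: < 0.7 mL/min

Both compounds were tested in an ADME assay on cells (Hepatocyte, Canis lupus familiaris) for metabolic stability, read by LC-MS; a lower number here means slower removal, a higher number faster removal of the compound. Compound 1 gives < 0.65 mL/min, which is a limit of the assay rather than a number. Compound 2 gives < 0.7 mL/min, again a limit of the assay and not a number. So compound 2 stands at one of the two limits shown, (the limit of < 0.7 mL/min in this assay, at which 1 of the 2 values shown sits), and the other value sits at the limit of < 0.65 mL/min in this assay, at which 1 of the 2 values shown sits; neither compound has a numerical reading, and the two cannot be ordered against each other.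

Compound 3 `CNC(=O)c1cc(C(=O)N[C@H]2CC[C@H](OC)CC2)n([C@@H](C)c2ccccc2)n1` has not yet been measured in this assay. It differs from compound 2 in one place: methyl in place of hydrogen on an oxygen on a saturated carbon. Among the measured compounds shown here, no step between two measured compounds is available here, since both readings are limits. For compound 3, the expectation is a step from the limit of compound 2 that is at most modest, on the side of faster removal, and possibly none beyond the usual scatter. In this assay compound 3 is estimated to give 1 mL/min, expected to fall between 0.4 mL/min and 3 mL/min. That estimate is expected to correspond to a step of an at least 1.4-fold higher number from compound 2 to compound 3 (0.15 log units; that floor lies within the scatter).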

Compound 3, intrinsic clearance in a liver preparation (reported as CLH), per the amount of preparation that the assay uses: < 0.65 mL/min
Compound 3 was reported as a limit; the forecaster's own chance of this, stated with the estimate: 40%; middle value at least 1.5-fold (0.18 log units) from the limit.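

In this assay, among the compounds shown here, compound 2 and compound 3 are both reported only as limits of the assay and not as numbers, so no step between them can be read. The compounds shown leave open how fast each is actually removed, and whether going from hydroxy to methoxy changes that at all.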